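Halogenated aryl ketones on a shared core: a second chloro

The compounds below may be only part of what the source reports. "The series", "measured", "known", "first", "only" and "open" are said of these compounds alone.

Compound 1 `Nc1sc2c(c1C(=O)c1cccc(Cl)c1)CCCC2` gives 10500 nM in an assay with adenosine receptor A1 (Rattus norvegicus) as the target; on this read-out higher numbers stand for an effect only at larger amounts of compound and lower numbers for an effect already at smaller amounts; this is the highest of the two numbers obtained so far. Compound 2 `Nc1sc2c(c1C(=O)c1ccc(I)cc1)CCCC2` gives 4500 nM in this assay, a lower number than compound 1 by a margin beyond the usual scatter. Compound 3 `Nc1sc2c(c1C(=O)c1ccc(Cl)c(Cl)c1)CCCC2` has not yet been measured; it differs from compound 1 by chloro in place of hydrogen on an aromatic carbon. Among the measured compounds shown here, no measured pair on the shared core shows this change, so the size of the step is open. Because compound 2 gives 4500 nM, a lower number than that of compound 1 already exists within this small set, and a downward step of moderate size, beyond the scatter, is expected from compound 1 to compound 3, a 3.5-fold lower number from compound 1 to compound 3 (0.54 log units; beyond the scatter). On that basis compound 3 is estimated at 3000 nM, with a range from 900 nM to 10000 nM.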

Compound 3, half-maximal effective concentration: 6200 nM
Compound 3: middle estimate off by 2.1-fold (0.32 log units), on the low side; the range from low to high includes it.
By their numbers in this assay, from the lowest: compounds 2, 3 and 1 (each within the scatter of the next, the first and the last beyond it).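

In this assay, among the compounds shown here, chloro in place of hydrogen on an aromatic carbon, ortho to a chloro group and para to a large group, gives a 1.7-fold lower number from compound 1 to compound 3 (0.23 log units; within the scatter), the first step on the shared core that can be read as a change in one place. At this position, then, a second chloro leaves the number within the scatter of that of compound 1, so this single step shows no clear effect of the change in either direction. No measured data on the compounds shown offer an explanation for this result.

As far as these compounds go, whether another group at this position, such as methoxy, an amine or a carboxylic acid, would give a step beyond the scatter remains open. Also open, from the compounds shown here alone, is whether the same chloro would give a similar step on a ring carrying no other chloro.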